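Compound 2 to compound 3: pyrrolidin-1-yl to piperidin-1-yl

This account rests on a few compounds, and the source may have more. Where it says the series, first, only, none or still open, it means among the compounds named here.

Measured in a physicochemical assay for solubility, in phosphate buffer, at pH 7.4 (a lower number here means a less soluble compound, a higher number a more soluble compound), so far:
- compound 1 `CC(=O)N1CCC(c2cc3c(-c4ccc(=O)n(C(C)C)c4)ccnc3[nH]2)CC1` gives 27000 nM 
- compound 2 `CC(C)n1cc(-c2ccnc3[nH]c(C4CCN(CC(=O)N5CCCC5)CC4)cc23)ccc1=O` gives 260000 nM 

Compound 2 holds the higher of the two numbers. Among the compounds with values here, the one measured step is a 9.6-fold higher number from compound 1 to compound 2 (0.98 log units; beyond the scatter) and it puts ((pyrrolidin-1-yl)carbonyl)methyl in place of acetyl on an amine nitrogen in a ring.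

Compound 3 `CC(C)n1cc(-c2ccnc3[nH]c(C4CCN(CC(=O)N5CCCCC5)CC4)cc23)ccc1=O` differs from compound 2 in one place, with piperidin-1-yl in place of pyrrolidin-1-yl on a carbonyl carbon. The group on the ring nitrogen stays ((piperidin-1-yl)carbonyl)methyl in type, and only the ring on the carbonyl carbon changes. Within the data shown here, no measured pair isolates this exchange, so the step from compound 1 bears on it only loosely. That step replaced the whole group, so a change well short of a 9.6-fold higher number from compound 1 to compound 2 (0.98 log units; beyond the scatter) is expected here. The two compounds give no direction for it, and no step beyond the scatter is expected. The estimated step is a 1.2-fold lower number from compound 2 to compound 3 (0.07 log units; within the scatter) (a slight fall is assumed only as a middle value). Compound 3 is estimated at 220000 nM in this assay (expected range 100000 nM to 450000 nM).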

Compound 3, solubility: 79000 nM
For compound 3 the middle estimate is 2.8-fold (0.44 log units) above the measured one, and the stated range ends above it.
By their numbers in this assay, from the lowest: compound 1; then compound 3; then compound 2.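

In this assay, the ring on the carbonyl carbon matters within the ((pyrrolidin-1-yl)carbonyl)methyl type of group: piperidin-1-yl in place of pyrrolidin-1-yl gives a 3.3-fold lower number from compound 2 to compound 3 (0.52 log units; beyond the scatter). The exchange goes from 5 heavy atoms to 6, with 0 hydrogen-bond donors, 0 hydrogen-bond acceptors and no net charge on either side, so a change this small in those counts still produces a step beyond the scatter. Replacing acetyl on the amine nitrogen still raises the number with the larger ring, but the step is smaller: a 2.9-fold higher number from compound 1 to compound 3 (0.47 log units; beyond the scatter), against a 9.6-fold higher number from compound 1 to compound 2 (0.98 log units; beyond the scatter), so the size of the rise over compound 1 depends on the ring and not only on the ((...)carbonyl)methyl type of group.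

Nothing measured here accounts for the difference between the two rings. As far as these compounds go, how an azetidin-1-yl or a morpholin-4-yl ring on the same carbonyl carbon would compare with compound 2 and compound 3 remains open, as does whether these two rings mark any trend with ring size.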